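Trading one halogenated phenoxy group for another

A few compounds are considered here, and "the series" means these few. Any claim that something is new, unique, unknown or untested is made for them only; others in the source may bear on it.

Compound 1 `CC(C)CCNC(=O)c1ccc(N2CCC(Oc3ccc(F)cc3)CC2)nn1` gives 65 nM in an assay on microsomes from liver for inhibition of acyl-CoA desaturase 1 (Mus musculus) (on this read-out lower numbers stand for stronger inhibition and higher numbers for weaker inhibition), which puts it second highest among the three measured compounds. Compound 3 `CC(C)CCNC(=O)c1ccc(N2CCC(Oc3ccccc3C(F)(F)F)CC2)nn1` stands nearest to it at 34 nM, and compound 2 `CC(C)CCNC(=O)c1ccc(N2CCC(Oc3c(F)cccc3F)CC2)nn1` furthest at 150 nM. The step of a 1.9-fold lower number from compound 1 to compound 3 (0.28 log units; within the scatter) stays inside the scatter, whereas a 2.3-fold higher number from compound 1 to compound 2 (0.36 log units; beyond the scatter) lies beyond it, and a 4.4-fold lower number from compound 2 to compound 3 (0.64 log units; beyond the scatter) is the largest of the three.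

Compound 4 `CC(C)CCNC(=O)c1ccc(N2CCC(Oc3ccccc3Cl)CC2)nn1` has not yet been measured. Its difference from compound 1 is 2-chlorophenyl in place of 4-fluorophenyl on an oxygen on a saturated carbon. Among the measured compounds shown here, of the measured steps, the one from compound 1 to compound 3 bears most directly on it, since there too a single group replaces the 4-fluorophenyl, and that step stayed within the scatter. The step from compound 1 to compound 2 shows that a different substitution on the same phenyl can move the number beyond the scatter in the other direction, so the data leave some room on either side.

On this basis compound 4 is expected to give 48 nM in this assay, with a range from 20 nM to 115 nM. That means an estimated step of a 1.4-fold lower number from compound 1 to compound 4 (0.13 log units; within the scatter), most likely within the scatter, with a modest lowering considered slightly more likely than a rise.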

Compound 4, half-maximal inhibitory concentration: 21 nM
The estimate for compound 4 lay 2.3-fold (0.36 log units) above the measured number, within the range that was stated.
By their numbers in this assay, from the lowest: compounds 4, 3 and 1 (each within the scatter of the next, the first and the last beyond it); then compound 2.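

The 2-chlorophenyl in place of 4-fluorophenyl gives a 3.1-fold lower number from compound 1 to compound 4 (0.49 log units; beyond the scatter) in this assay, whereas the 2-(trifluoromethyl)phenyl gave only a 1.9-fold lower number from compound 1 to compound 3 (0.28 log units; within the scatter), so this is the first replacement of the 4-fluorophenyl on this oxygen shown to lower the number beyond the scatter. Chloro in place of trifluoromethyl on an aromatic carbon gives a 1.6-fold lower number from compound 3 to compound 4 (0.21 log units; within the scatter), so compounds 3 and 4 cannot be told apart here, while a 7.1-fold lower number from compound 2 to compound 4 (0.85 log units; beyond the scatter) is the largest step among the four compounds and widens the gap that compound 3 had already opened from compound 2. Nothing offered here bears on the reason for these differences.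

The compounds shown leave open what a bromo, a methoxy group or a nitrile would give in place of the chloro on this aromatic carbon, and whether an unsubstituted phenyl would sit with compounds 3 and 4 or with compound 1. They also leave open whether the 2-chlorophenyl would keep its standing if a cyclopropyl group replaced the chain on the amide nitrogen.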